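The source may report more compounds than this note shows. Statements on the series, on what has been measured and on what is new or still open speak of the compounds shown alone.

Measured so far, in a functional assay on cells for positive allosteric modulation of metabotropic glutamate receptor 5 (Rattus norvegicus), read by calcium flux; on this read-out lower numbers stand for an effect already at smaller amounts and higher numbers for an effect only at larger amounts of compound:
compound 1, `COc1cccc(C(=O)Nc2cc(-c3ccccc3)nn2-c2ccccc2)c1`: 102 nM
compound 2, `O=C(Nc1cc(-c2ccccc2)nn1-c1ccccc1)c1cccc([N+](=O)[O-])c1`: 39 nM
compound 3, `O=C(Nc1cc(-c2ccccc2)nn1-c1ccccc1)c1ccc(C(F)(F)F)cc1`: 38 nM

All three compounds share the same core and differ only in the aryl group on the carbonyl carbon of the amide. Compound 3 stands at the lowest number of the three; its number and that of compound 2 lie within the scatter of each other, so no order between them can be read, while compound 1 sits clearly higher, as the step of a 2.7-fold lower number from compound 1 to compound 3 (0.43 log units; beyond the scatter) shows. Compound 2 shows the same pattern against compound 1 in a 2.6-fold lower number from compound 1 to compound 2 (0.42 log units; beyond the scatter).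

Compound 4, `COc1cc(OC)cc(C(=O)Nc2cc(-c3ccccc3)nn2-c2ccccc2)c1`, has not yet been measured. It differs from compound 3 in one place: 3,5-dimethoxyphenyl in place of 4-(trifluoromethyl)phenyl on a carbonyl carbon. Within the data shown here, the steps that bear on this change are those leading away from the methoxy-bearing aryl of compound 1: a 2.7-fold lower number from compound 1 to compound 3 (0.43 log units; beyond the scatter) and a 2.6-fold lower number from compound 1 to compound 2 (0.42 log units; beyond the scatter), both modest and both beyond the scatter. Returning to a methoxy-bearing aryl is therefore expected to move the number back toward that of compound 1, a modest step upward. The estimate for compound 4 in this assay is 100 nM, within the range 35 nM to 300 nM, which amounts to an expected step of a 2.6-fold higher number from compound 3 to compound 4 (0.42 log units; beyond the scatter).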

Compound 4, half-maximal effective concentration: 2040 nM
Compound 4: the middle estimate sits 20-fold (1.31 log units) below what was measured; measured number above the stated range.
By their numbers in this assay, from the lowest: compounds 3 and 2 (each within the scatter of the next); then compound 1; then compound 4.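

In this assay, one more methoxy on an aromatic carbon of the aryl group gives a 20-fold higher number from compound 1 to compound 4 (1.30 log units; beyond the scatter) and so counts for far more than any step among the first three compounds, which were modest at most. Set against the two aryl groups without methoxy, 3,5-dimethoxyphenyl gives a 54-fold higher number from compound 3 to compound 4 (1.73 log units; beyond the scatter) and a 52-fold higher number from compound 2 to compound 4 (1.72 log units; beyond the scatter) even though it has the same number of heavy atoms as the 4-(trifluoromethyl)phenyl it replaces, so the heavy-atom count alone does not predict the number at this place on the carbonyl carbon. No measurement here accounts for why the change is so large.

Going by these compounds, it remains open whether the jump belongs to the methoxy groups themselves or to any pair of groups in those places on the ring, which two methyl groups or two chlorine atoms in place of the two methoxy groups could help to separate. On these data alone, how an amine or a carboxylic acid on this aryl ring would move the number also stays unknown.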